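Crossing the Cell Layer: From Compound 3 to Compound 4

The source may report more compounds than this note shows. Statements on the series, on what has been measured and on what is new or still open speak of the compounds shown alone.

Compound 1 `CC(C)(C)[C@@H](O)C(=O)N1CSC[C@H]1C(=O)NCc1cc(Cl)ccc1-n1cnnn1`: 19 10^-6 cm/s
Compound 2 `O=C(NCc1cc(Cl)ccc1-n1cnnn1)[C@@H]1[C@H]2C[C@H]2CN1C(=O)[C@H](O)CC1CC1`: 3.4 10^-6 cm/s
Compound 3 `COC(C)(C)[C@@H](O)C(=O)N1N=CC[C@H]1C(=O)NCc1cc(Cl)ccc1-n1cnnn1`: 1.7 10^-6 cm/s

These values come from an ADME assay on Caco-2 cells (Homo sapiens) for permeability, read by LC-MS, in the apical to basolateral direction, with a stated time of 60 min, at pH 6.5; a higher number here means that the compound crosses the layer faster, a lower number that the compound crosses the layer more slowly. Compound 3 stands lowest of the three, but its number sits within the scatter of that of compound 2, so the two cannot be ordered; compound 1 lies well beyond it. Compound 4 `Cc1cccc([C@@H](O)C(=O)N2N=CC[C@H]2C(=O)NCc2cc(Cl)ccc2-n2cnnn2)c1` has not yet been measured. It differs from compound 3 in one place: 3-methylphenyl in place of 1-methoxy-1-methylethyl on a saturated chain carbon bound to a carbonyl carbon and an oxygen on a saturated carbon. For the measured compounds named here, no pair of measured compounds differs in exactly one place, so no measured step guides this change directly. The entering group carries no hydrogen-bond acceptor, and compound 1, whose corresponding group also has none, gives 19 10^-6 cm/s. A moderate rise is therefore expected in this assay, the step being a 2.9-fold higher number from compound 3 to compound 4 (0.47 log units; beyond the scatter). Compound 4 is estimated at 5 10^-6 cm/s, with a range from 1.5 10^-6 cm/s to 15 10^-6 cm/s.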

Compound 4, apparent permeability: 9.7 10^-6 cm/s
Beside the measured number, compound 4's estimate is 1.9-fold (0.29 log units) below it, within the range that was stated.
By their numbers in this assay, from the lowest: compounds 3 and 2 (each within the scatter of the next); then compounds 4 and 1 (each within the scatter of the next).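

In this assay, for the compounds shown here, the swap of 1-methoxy-1-methylethyl for 3-methylphenyl gives the first single-change step at this position, a 5.7-fold higher number from compound 3 to compound 4 (0.76 log units; beyond the scatter). So an aromatic ring of carbon only can stand here with a number beyond the scatter on the higher side, while the entering group has no hydrogen-bond acceptor and the leaving group has one. Nothing measured here explains the rise. The compounds shown leave open whether the ring, its methyl or the lost oxygen matters. A plain phenyl or a methoxyphenyl at this position could separate these.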